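This account rests on a few compounds, and the source may have more. Where it says the series, first, only, none or still open, it means among the compounds named here.

Measured compounds:
Compound 1 `COc1ccccc1NC(=O)Oc1cc(=O)n(CCCO)c2c1CC(CC=C(C)C)C(C)(C)C2` gives 0% in a functional assay on PANC-1 cells (Homo sapiens) for inhibition, read by MTT assay, with a stated time of 24 h, tested at 10 uM; a lower number here means less inhibition, a higher number more inhibition at the concentration tested (going by the name of the read-out).
Compound 2 `CC(C)=CCC1Cc2c(OC(=O)Nc3ccc(F)cc3F)cc(=O)n(CCCO)c2CC1(C)C` gives 0%.
Compound 3 `CC(C)=CCC1Cc2c(OC(=O)Nc3ccc(Cl)cc3)cc(=O)n(CCCO)c2CC1(C)C` gives 0%.

Compound 3 stands level with compounds 1 and 2 at the digits reported: no change at the digits printed from compound 1 to compound 3 (within the scatter) and no change at the digits printed from compound 2 to compound 3 (within the scatter), and between the other two no change at the digits printed from compound 1 to compound 2 (within the scatter). Every measured step exchanges the aryl group on the amide-type nitrogen and none moved the read-out beyond the scatter.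

Compound 4 `CC(C)=CCC1Cc2c(OC(=O)Nc3cccc(C(F)(F)F)c3)cc(=O)n(CCCO)c2CC1(C)C` is the next exchange at that same position: 3-(trifluoromethyl)phenyl in place of 4-chlorophenyl on an amide-type nitrogen. Since the three aryl exchanges already measured were flat, as no change at the digits printed from compound 1 to compound 3 (within the scatter) and no change at the digits printed from compound 2 to compound 3 (within the scatter) show, the step to compound 4 is expected to be flat as well, no change at the digits printed from compound 3 to compound 4 (within the scatter). Compound 4 is therefore estimated at 0%, with a range from 0% to 10%.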

Compound 4, a percentage reported as inhibition, at one concentration (the size of the read-out at that concentration, not a potency): 0%
Compound 4: the middle estimate sits on the measured number at the digits printed; measured number inside the range.
By their numbers in this assay, from the lowest: compounds 1, 2, 3 and 4 (each within the scatter of the next).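

In this assay, replacing 4-chlorophenyl on the amide-type nitrogen with the larger 3-(trifluoromethyl)phenyl, 10 heavy atoms in place of 7, gives no change at the digits printed from compound 3 to compound 4 (within the scatter). The same group also gives no change at the digits printed from compound 2 to compound 4 (within the scatter) and no change at the digits printed from compound 1 to compound 4 (within the scatter), so a fourth aryl group on this nitrogen, now carrying trifluoromethyl, leaves the read-out where the others stood. No evidence is available that could explain this flat result.

With every compound at the same reading, the compounds shown do not reveal whether any aryl exchange matters here. As far as these compounds go, whether an amine or a carboxylic acid on this aryl ring, or an alkyl group in its place, would change the read-out remains open.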